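This account rests on a few compounds, and the source may have more. Where it says the series, first, only, none or still open, it means among the compounds named here.

Measured in a functional assay on U-87MG ATCC cells (Homo sapiens) for cytotoxicity, read by MTT assay, with a stated time of 48 h; on this read-out higher numbers stand for weaker inhibition and lower numbers for stronger inhibition:
Compound 1 `C/C(=N\NC(=S)Nc1ccc(I)cc1)c1ccccn1`: 59 nM
Compound 2 `CC(=NNC(=S)Nc1ccccc1)c1ccccn1`: 1.4 nM
Compound 3 `CC(=NNC(=S)Nc1ccc(I)cc1)c1ccccn1`: 59 nM

Compound 3 stands level with compound 1, with no change at the digits printed from compound 1 to compound 3 (within the scatter), and together they hold the highest of the three numbers. What separates the two is the fact that one of compounds 1 and 3 is drawn with a defined configuration and the other without, at the place where they differ, so this pair says nothing about the substituent on the aromatic ring. The next compound, compound 4 `CC(=NNC(=S)Nc1ccc(F)cc1)c1ccccn1`, carries fluoro in place of iodo on an aromatic carbon.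

Among the measured compounds shown here, only one measured step bears on this place: iodo in place of hydrogen on an aromatic carbon, with a 42-fold higher number from compound 2 to compound 3 (1.62 log units; beyond the scatter), which is large. For the measured compounds named here, no fluoro compound has been measured, so how much of that step fluoro would retain is open. A move towards a lower number in this assay is expected, probably smaller than the gap to compound 2 at 1.4 nM, though the range stays wide. The expected size of the change is a 5.9-fold lower number from compound 3 to compound 4 (0.77 log units; beyond the scatter). For compound 4 the estimated value is 10 nM, within an expected range of 1.5 nM to 60 nM.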

Compound 4, half-maximal inhibitory concentration: 10 nM
Compound 4: middle estimate and measured number agree at the digits printed; the measured number falls inside the stated range.
By their numbers in this assay, from the lowest: compound 2; then compound 4; then compounds 1 and 3 (each within the scatter of the next).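

In this assay, this place on the aromatic ring now has a second halogen to set against hydrogen, and the choice of halogen matters: a 5.9-fold lower number from compound 3 to compound 4 (0.77 log units; beyond the scatter). Fluoro does not return the number to the level of the unsubstituted compound, however, with a 7.1-fold higher number from compound 2 to compound 4 (0.85 log units; beyond the scatter), so both halogens give higher numbers than hydrogen, while the step for fluoro is the smaller of the two. Nothing given here accounts for the difference between fluoro and iodo at this place.

On these data alone, whether chloro or bromo would fall between fluoro and iodo remains open, as does the effect of a methoxy group or an amine at this place. As far as these compounds go, it is also open whether fluoro would give a similar step elsewhere on the ring.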